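The source may report more compounds than this note shows. Statements on the series, on what has been measured and on what is new or still open speak of the compounds shown alone.

Going by the values given here, in an in vitro ADME assay on microsomes (Homo sapiens) for metabolic stability (on this read-out higher numbers stand for a longer-lived compound and lower numbers for a shorter-lived compound), compound 2 `CCc1nc(NC(CC)CC)cnc1-c1ccc(Cl)cc1Cl` gives 0.467 h, the highest of the two numbers so far, while compound 1 `CCc1nc(NC(CC)CC)c(Cl)nc1-c1ccc(Cl)cc1Cl` gives 0.167 h. Compound 3 `CCOc1nc(-c2ccc(Cl)cc2Cl)c(CC)nc1NC(CC)CC` has not yet been measured. It differs from compound 2 as follows: ethoxy in place of hydrogen on an aromatic carbon. Among the compounds with values here, one measured step bears on this change: a 2.8-fold higher number from compound 1 to compound 2 (0.45 log units; beyond the scatter), where hydrogen replaces chloro on that same aromatic carbon. Read in reverse, this modest step shows the chloro of compound 1 going with the lower number, though chloro is not ethoxy and no ethoxy compound has yet been measured. The expected change is a 2.3-fold lower number from compound 2 to compound 3 (0.37 log units; beyond the scatter), an estimated downward step of similar size, held with wide uncertainty. The estimated value for compound 3 is 0.2 h, with an expected range from 0.08 h to 0.45 h.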

Compound 3, half-life: 2 h
Compound 3: middle estimate off by 10-fold (1.00 log units), on the low side; measured number above the stated range.
By their numbers in this assay, from the lowest: compound 1; then compound 2; then compound 3.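

In this assay, going by these compounds alone, the earlier compounds had only linked a group on this aromatic carbon, next to the ring nitrogen, with a lower number, but ethoxy in place of hydrogen gives a 4.3-fold higher number from compound 2 to compound 3 (0.63 log units; beyond the scatter) and so reverses that direction. Set against chloro at the same carbon, ethoxy gives a 12-fold higher number from compound 1 to compound 3 (1.08 log units; beyond the scatter) and the three compounds rise in the order chloro, hydrogen, ethoxy, so the direction of the change depends on which group sits there and not merely on the carbon bearing a substituent. Nothing available explains why chloro and ethoxy part in this way.

The compounds shown leave open whether the gain follows the ether oxygen or the length of the chain, which methoxy, propoxy or a plain propyl group at this carbon would separate. Going by these compounds, an amine there is equally open.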